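Swapping the aryl group on the shared core

The source may hold more compounds than are shown below. What is called first, only, known or untested is meant among the compounds shown, and "the series" means these compounds.

Compound 1, `COc1ccc(C2=C(c3ccc(SC)cc3)CC3CCCN3C2=O)cc1Br`, gives 6000 nM in a functional assay on MCF-A cells (Homo sapiens) for cytotoxicity; a higher number here means a weaker inhibitor of growth, a lower number a stronger inhibitor of growth.
Compound 2, `COc1ccc(C2=C(c3ccc(SC)cc3)CC3CCCN3C2=O)cc1C`, gives 400 nM in this assay.
Compound 3, `CSc1ccc(C2=C(c3ccc(O)cc3)C(=O)N3CCCC3C2)cc1`, reaches only a limit of the assay, > 100000 nM, in this assay.

Among the numbers shown, compound 1 stands highest of the two real numbers; its nearest neighbour is compound 2, a step of a 15-fold lower number from compound 1 to compound 2 (1.18 log units; beyond the scatter), while compound 3 sits at a limit rather than a number (the limit of > 100000 nM in this assay, at which 1 of the 3 values shown sits).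

Compound 4, `CSc1ccc(C2=C(c3ccc(C)cc3)C(=O)N3CCCC3C2)cc1`, differs from compound 1 in one place: 4-methylphenyl in place of 3-bromo-4-methoxyphenyl on a double-bonded ring carbon.

For the measured compounds named here, two measured steps touch this position. Replacing the aryl group of compound 1 with 4-hydroxyphenyl gave an at least 16-fold higher number from compound 1 to compound 3 (1.22 log units; beyond the scatter), and the same replacement from compound 2 gave an at least 250-fold higher number from compound 2 to compound 3 (2.39 log units; beyond the scatter). Both point to a weaker growth inhibitor when the 3-bromo-4-methoxyphenyl or 4-methoxy-3-methylphenyl group is lost, though 4-methylphenyl is not 4-hydroxyphenyl, so the size of the effect for compound 4 is uncertain. A step of a 2.0-fold higher number from compound 1 to compound 4 (0.30 log units; within the scatter) toward a higher number is therefore expected. Compound 4 is estimated at 12000 nM, with a range from 2000 nM to 100000 nM in this assay.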

Compound 4, concentration for 50% growth inhibition: 600 nM
Compound 4: middle estimate off by 20-fold (1.30 log units), on the high side, and the stated range ends above it.
By their numbers in this assay, from the lowest: compounds 2 and 4 (each within the scatter of the next); then compound 1. At a limit, above all of these: compound 3.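

Losing the 3-bromo-4-methoxyphenyl group does not in itself weaken growth inhibition in this assay: with 4-methylphenyl on this double-bonded ring carbon there is a 10-fold lower number from compound 1 to compound 4 (1.00 log units; beyond the scatter), and replacing 4-methoxy-3-methylphenyl gives a 1.5-fold higher number from compound 2 to compound 4 (0.18 log units; within the scatter). The sharp loss seen earlier therefore follows the hydroxy group rather than the absence of the methoxy group, since methyl in place of hydroxy gives an at least 160-fold lower number from compound 3 to compound 4 (2.22 log units; beyond the scatter). The value of compound 3 is a limit of the assay, not a number, so that step has no exact size: the limit of > 100000 nM in this assay, at which 1 of the 4 values shown sits.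

The compounds shown leave open whether an amine, a carboxylic acid or a longer chain such as ethyl in place of that methyl would behave like methyl or like hydroxy. They also give no reading of a plain phenyl group on this carbon.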